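The source may report more compounds than this note shows. Statements on the series, on what has been measured and on what is new or still open speak of the compounds shown alone.

Measured compounds in an in vitro assay on cells for inhibition of Amine oxidase [flavin-containing] B (Homo sapiens), read by fluorescence and Amplex Red, with stated times of 30 min and 45 min; on this read-out higher numbers stand for weaker inhibition and lower numbers for stronger inhibition:
compound 1 `O=C(CCCc1ccccc1)Nc1nc2cc(Cl)ccc2c(=O)s1` gives 76.4 nM;
compound 2 `O=C(CCCc1ccccc1)Nc1nc2ccccc2c(=O)s1` gives 34.9 nM;
compound 3 `O=C(CCCc1ccccc1)Nc1nc2ccc(Br)cc2c(=O)s1` gives a limit of this assay, > 10000 nM.

Compound 2 gives the lowest of the two numbers; compound 1 lies nearest, with a 2.2-fold lower number from compound 1 to compound 2 (0.34 log units; beyond the scatter). The step of an at least 280-fold higher number from compound 2 to compound 3 (2.45 log units; beyond the scatter) reaches only a limit (the limit of > 10000 nM in this assay, at which 1 of the 3 values shown sits). Compound 4 `O=C(CCCc1cccc(Cl)c1)Nc1nc2ccccc2c(=O)s1` differs from compound 2 by chloro in place of hydrogen on an aromatic carbon, on a six-membered aromatic ring of carbon only, meta to a large group. Both measured steps move a halogen on the shared core, not on this ring, so neither bears directly on the step to compound 4. A step of no more than modest size is therefore expected in this assay, in either direction, as a 1.1-fold higher number from compound 2 to compound 4 (0.06 log units; within the scatter). Compound 4 is estimated at 40 nM, between 15 nM and 120 nM.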

Compound 4, half-maximal inhibitory concentration: > 1000 nM
Compound 4 was reported as a limit; the forecaster's own chance of this, stated with the estimate: 5%; middle value at least 25-fold (1.39 log units) from the limit.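

Phenyl to 3-chlorophenyl brings an at least 28-fold higher number from compound 2 to compound 4 (1.45 log units; beyond the scatter), so a single chloro on this ring, outside the shared core, can also weaken inhibition sharply. Earlier, only halogens on the shared core had been compared, and those steps differed widely in size, with compound 1 showing a modest one and compound 3 a large one. Compound 4 gives a limit and not a number: the limit of > 1000 nM in this assay, at which 1 of the 4 values shown sits.

The compounds shown leave open whether the loss is specific to chloro or would also follow fluoro, methoxy or an amine at this place. They also leave open how the other places on this ring would respond.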